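The source may report more compounds than this note shows. Statements on the series, on what has been measured and on what is new or still open speak of the compounds shown alone.

Compound 1 `O=C(COc1cccc2ccccc12)N/N=C/c1ccc([N+](=O)[O-])cc1` in an ADME assay on HEL cells (Homo sapiens) for cytotoxicity (a higher number here means that more compound is tolerated, a lower number that less compound is tolerated), gives 20 ug/mL. Compound 3 `C/C(=N\NC(=O)COc1cccc2ccccc12)c1ccccc1Br` gives 20 ug/mL in this assay, no change from compound 1 at the digits read and within the scatter; these two together sit at the low end of the three numbers. Compound 2 `COc1cc(/C=N/NC(=O)COc2cccc3ccccc23)cc(OC)c1O` gives 100 ug/mL in this assay, the furthest from compound 1 and a gap beyond the scatter. Compound 4 `CSc1ccc(/C=N/NC(=O)COc2cccc3ccccc23)cc1` is not yet measured in this assay; against compound 1 the difference is methylsulfanyl in place of nitro on an aromatic carbon. Among the compounds with values here, no measured pair shows this change, so no size of step can be read from the data; the expected step is no change at the digits printed from compound 1 to compound 4 (within the scatter), none beyond the scatter. For compound 4 the estimated value in this assay is 20 ug/mL, with a range from 10 ug/mL to 60 ug/mL.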

Compound 4, minimum cytotoxic concentration: >= 100 ug/mL
Compound 4 gave a limit, no number (the forecaster's own chance of this, stated with the estimate: 10%); middle value at least 5.0-fold (0.69 log units) away from the limit.
By their numbers in this assay, from the lowest: compounds 1 and 3 (each within the scatter of the next); then compound 2.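

On the aromatic carbon para to a large group, methylsulfanyl in place of nitro gives an at least 5.0-fold higher number from compound 1 to compound 4 (0.69 log units; beyond the scatter) in this assay. Within the data shown here, this is the first step that can be read at a single place, and it shows that this position can move the tolerated concentration beyond the scatter. Compound 4 gives >= 100 ug/mL, which is a limit of the assay and not a number.

As far as these compounds go, whether the step comes from losing nitro or from gaining methylsulfanyl stays open, as does its full size. An amine or a carboxylic acid on the same carbon would help to separate the two.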